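The compounds below may be only part of what the source reports. "The series", "measured", "known", "first", "only" and "open" are said of these compounds alone.

Measured compounds:
- compound 1, `CCOc1ccc(N)cc1-c1ncc(C(=O)O)c(=O)[nH]1`, 1.2 mg/kg
- compound 2, `CCOC(=O)C(=O)Nc1ccc(OCC)c(-c2ncc(C(=O)O)c(=O)[nH]2)c1`, 25 mg/kg

In a functional assay on the whole organism (strain Sprague-Dawley) for inhibition, with Rattus norvegicus as the target, with a stated time of 10 min (on this read-out higher numbers stand for an effect only at larger amounts of compound and lower numbers for an effect already at smaller amounts), compound 2 stands highest of the two numbers; its nearest neighbour is compound 1, which gives 1.2 mg/kg, a gap that lies beyond the scatter. Within the data shown here, the one step that joins them, a 21-fold higher number from compound 1 to compound 2 (1.32 log units; beyond the scatter), is large. Compound 3, `CCOc1ccc(S(N)(=O)=O)cc1-c1ncc(C(=O)O)c(=O)[nH]1`, differs from compound 2 in one place: sulfamoyl in place of ((ethoxycarbonyl)carbonyl)amino on an aromatic carbon. The step from compound 1 to compound 2 bears on this change only in part, since it shows what happens when the (ethoxycarbonyl)carbonyl group is added, not what a sulfamoyl group does in its place. Among the measured compounds shown here, no measured compound carries a sulfamoyl group, so the expectation must stay loose. Removing the ((ethoxycarbonyl)carbonyl)amino group is expected to bring compound 3 closer to compound 1, so a step of a 4.2-fold lower number from compound 2 to compound 3 (0.62 log units; beyond the scatter) is expected. The estimate for compound 3 in this assay is 6 mg/kg, with a range from 1.2 mg/kg to 30 mg/kg.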

Compound 3, dose for 50% inhibition: > 50 mg/kg
Compound 3 gave a limit, no number; the forecaster's own chance of this, stated with the estimate: 10%; middle value at least 8.3-fold (0.92 log units) away from the limit.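

At the aromatic carbon para to an ethoxy group, the sulfamoyl group gives compound 3 no number in this assay, only a limit: the limit of > 50 mg/kg in this assay, at which 1 of the 3 values shown sits.

Set against the amino group, the change is plain, with an at least 41-fold higher number from compound 1 to compound 3 (1.61 log units; beyond the scatter), so among the three groups shown, the amino group of compound 1 gives an effect at the smallest amount. Against ((ethoxycarbonyl)carbonyl)amino the reading is weaker, with an at least 2.0-fold higher number from compound 2 to compound 3 (0.30 log units; that floor lies within the scatter), so this comparison alone does not separate the two groups.

As far as these compounds go, how far the true dose for compound 3 lies beyond its limit stays open. Also open, from the compounds shown here alone, is whether a methylamino or acetylamino group on the same carbon would keep the effect seen with the amino group.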